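Replacing trifluoromethyl with piperazin-1-yl in compound 3

The compounds below may be only part of what the source reports. "The series", "measured", "known", "first", "only" and "open" are said of these compounds alone.

Measured in a physicochemical assay for solubility, at pH 2; a higher number here means a more soluble compound, a lower number a less soluble compound:
- Compound 1 `CNc1nc(NCCCN(C)C)c2sc(-c3ccc(N)cc3)cc2n1` gives > 100 ug/mL, which is a limit.
- Compound 2 `CNc1nc(NCCCN(C)C)c2sc(-c3ccc(S(C)(=O)=O)cc3)cc2n1` gives > 100 ug/mL, which is a limit.
- Compound 3 `CNc1nc(NCCCN(C)C)c2sc(-c3ccc(C(F)(F)F)cc3)cc2n1` gives 240 ug/mL.

Compound 3 is the only one of the three with an actual number in this assay, so it cannot be ranked against the other two. Beside that number stands (the limit of > 100 ug/mL in this assay, at which 2 of the 3 values shown sit).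

The structural change to compound 4 `CNc1nc(NCCCN(C)C)c2sc(-c3ccc(N4CCNCC4)cc3)cc2n1` is piperazin-1-yl in place of trifluoromethyl on an aromatic carbon, para to a large group.

Two measured steps end at compound 3 and bear on this position: a step that the limit leaves unreadable from compound 1 to compound 3 and a step that the limit leaves unreadable from compound 2 to compound 3. Neither offers a size to carry over, and neither offers a direction. No step beyond the usual scatter is therefore expected in this assay, and the estimate stays anchored on compound 3 at 240 ug/mL. The expected change is a 1.0-fold higher number from compound 3 to compound 4 (0.02 log units; within the scatter). For compound 4 the estimated value is 250 ug/mL, with an expected range from 120 ug/mL to 500 ug/mL.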

Compound 4, solubility: > 100 ug/mL
Compound 4 gave a limit, no number; the forecaster's own chance of this, stated with the estimate: 55%; the middle value is on the limit's open side.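

In this assay compound 4 gives > 100 ug/mL, which is a limit and not a number. Among the compounds shown here, no step to compound 4 from compound 1, compound 2 or compound 3 can be read. Whether these four compounds truly differ in this assay stays open, as only compound 3 carries an actual number: the limit of > 100 ug/mL in this assay, at which 3 of the 4 values shown sit.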